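The source may hold more compounds than are shown below. What is called first, only, known or untested is meant among the compounds shown, and "the series" means these compounds.

Compound 1 `C=CCn1c(=O)/c(=C\c2ccccc2OC)[nH]c(=O)/c1=C\c1ccccc1OC` is the reference point among the measured compounds, and in a functional assay on NCI-H1975 cells (Homo sapiens) for cytotoxicity, read by CCK-8 assay, with a stated time of 72 h (a lower number here means a stronger inhibitor, a higher number a weaker inhibitor), compound 1 gives 21500 nM. Compound 2 `C=CCn1c(=O)/c(=C\c2cccc(Br)c2)[nH]c(=O)/c1=C\c1ccccc1OC` gives "not active" (no number reported) in this assay, so no single number is recorded for it, and compound 3 `C=CCn1c(=O)/c(=C\c2ccc(C)cc2)[nH]c(=O)/c1=C\c1ccccc1OC` likewise gives "not active" (no number reported) in this assay. Compound 2 therefore stands without a number, alongside one further compound in the same position. The step to compound 4 `C=CCn1c(=O)/c(=C\c2cccc(Br)c2)[nH]c(=O)/c1=C\c1cccc(Br)c1` is 3-bromophenyl in place of 2-methoxyphenyl on a double-bonded chain carbon bound to an aromatic carbon. Among the compounds with values here, no measured pair shows this change directly, and since compound 2 reports no number, the direction and size of the step in this assay cannot be drawn from the measured compounds; compound 4 is expected to remain weak. Compound 4 is estimated at 40000 nM in this assay, within a range of 10000 nM to 150000 nM.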

Compound 4, half-maximal inhibitory concentration: "not active" (no number reported)
Nothing numeric was reported for compound 4, and the estimate cannot be compared.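

In this assay compound 2 and compound 4 both stand without a number, and no step can be read between them. No evidence bears on this result. The compounds shown leave open how the 3-bromophenyl for 2-methoxyphenyl change acts on activity.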